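A few compounds are considered here, and "the series" means these few. Any claim that something is new, unique, unknown or untested is made for them only; others in the source may bear on it.

Measured so far:

- Compound 1, `Cc1cc(=O)n(-c2ccccc2OC(F)(F)F)nc1C(=O)Nc1ccc(Oc2ncnc3[nH]ccc23)cc1`, gives 32000 nM in a functional assay on MCF7 cells (Homo sapiens) for cytotoxicity, read by MTT assay, with a stated time of 72 h; on this read-out higher numbers stand for weaker inhibition and lower numbers for stronger inhibition.
- Compound 2, `Cc1cc(=O)n(-c2ccccc2OC(F)(F)F)nc1C(=O)Nc1ccc(Oc2ncnc3c2ccn3C)cc1`, gives 27000 nM in this assay.

Among the measured compounds shown here, compound 2 carries the lower of the two numbers, but the only step that leads to it, a 1.2-fold lower number from compound 1 to compound 2 (0.07 log units; within the scatter), lies within the scatter, so the two compounds are not separated by this read-out. Both sit at weak inhibition.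

Compound 3, `Cc1cc(=O)n(-c2cccc(F)c2)nc1C(=O)Nc1ccc(Oc2ncnc3c2ccn3C)cc1`, differs from compound 2 in one place: 3-fluorophenyl in place of 2-(trifluoromethoxy)phenyl on an aromatic nitrogen. For the measured compounds named here, no measured step bears on this change. Going by the values given here, the single step available concerns a methyl in place of hydrogen on an aromatic nitrogen at another position of the shared core, and it stayed within the scatter. Nothing here shows how exchanging the aryl group on the aromatic nitrogen of the shared core moves the number, so the plainest expectation is a step no larger than the scatter, in either direction, and an estimated no change at the digits printed from compound 2 to compound 3 (within the scatter) is what is expected here. Compound 3 is therefore expected to give about 27000 nM in this assay, with a range from 9000 nM to 80000 nM.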

Compound 3, half-maximal inhibitory concentration: 30800 nM
For compound 3 the middle estimate is 1.1-fold (0.06 log units) below the measured one, and the stated range covers the measured number.
By their numbers in this assay, from the lowest: compounds 2, 3 and 1 (each within the scatter of the next).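

Replacing 2-(trifluoromethoxy)phenyl with 3-fluorophenyl on the aromatic nitrogen gives, in this assay, a 1.1-fold higher number from compound 2 to compound 3 (0.06 log units; within the scatter), so this read-out does not separate the two compounds. Among the compounds shown here, the earlier pair dealt only with a methyl on a different aromatic nitrogen, whereas this pair is the first to alter the aryl group, and it shows that a smaller group with fluorine but no oxygen still leaves the compound at weak inhibition. No supporting measurement is available to explain this result.

This single step exchanges the substituent and its position on the phenyl ring together, so the effect of each alone cannot be read from it, and two aryl groups are too few to show how much this position can matter in general. On these data alone, it remains open whether a phenyl ring carrying an amine or a carboxylic acid, or a longer alkyl chain in place of the aryl group, would move the number beyond the scatter in this assay and turn this weak series into a stronger one.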